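The source may report more compounds than this note shows. Statements on the series, on what has been measured and on what is new or still open speak of the compounds shown alone.

In an ADME assay on HepG2 2.2.15 cells (Homo sapiens) for cytotoxicity (on this read-out higher numbers stand for lower toxicity in this test and lower numbers for higher toxicity in this test), compound 3 `CC(=O)N1CCC(C(=O)OCCc2c(-c3ccccc3Cl)c3cc(Cl)ccc3[nH]c2=O)CC1` gives 82000 nM, the highest of the two numbers read in this set. Compound 1 `O=C(OCCc1c(-c2ccccc2Cl)c2cc(Cl)ccc2[nH]c1=O)C1CCCC1` gives 46000 nM in this assay, and the step of a 1.8-fold higher number from compound 1 to compound 3 (0.25 log units; within the scatter) stays within the scatter, so compound 1 and compound 3 cannot be told apart. Compound 2 `CC12CCC(C(=O)OCCc3c(-c4ccccc4Cl)c4cc(Cl)ccc4[nH]c3=O)(OC1=O)C2(C)C` gives only a limit in this assay, > 1800000 nM. The edge of the measured range is the limit of > 1800000 nM in this assay, at which 1 of the 3 values shown sits. Against that limit the step of an at least 21-fold lower number from compound 2 to compound 3 (1.34 log units; beyond the scatter) is large, as is an at least 39-fold higher number from compound 1 to compound 2 (1.59 log units; beyond the scatter) in the other direction; all three exchanges sit on the same carbonyl carbon.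

Compound 4 `COc1ccc(/C=C/C(=O)OCCc2c(-c3ccccc3Cl)c3cc(Cl)ccc3[nH]c2=O)cc1` differs from compound 3 in one place: 2-(4-methoxyphenyl)ethenyl in place of 1-acetylpiperidin-4-yl on a carbonyl carbon. Within the data shown here, the measured steps at this carbonyl carbon run from within the scatter up to large ones, and no measured compound carries the entering group, so the guide is weak. A step within the scatter, or a modest one towards a lower number, is expected: a 1.5-fold lower number from compound 3 to compound 4 (0.17 log units; within the scatter). Compound 4 is estimated at 55000 nM, with a range from 15000 nM to 250000 nM.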

Compound 4, half-maximal cytotoxic concentration: > 1200000 nM
Compound 4: no number, only a limit (the forecaster's own chance of this, stated with the estimate: 10%); at least 21-fold (1.33 log units) between middle value and limit.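

In this assay, among these compounds, compound 4 gives only a limit, > 1200000 nM at this carbonyl carbon, so compound 2 is no longer the only compound at such a limit. Both an at least 14-fold higher number from compound 3 to compound 4 (1.16 log units; beyond the scatter) and an at least 26-fold higher number from compound 1 to compound 4 (1.41 log units; beyond the scatter) are large, so a large step at this place also comes with 2-(4-methoxyphenyl)ethenyl, which carries a six-membered aromatic ring of carbon only, and not with the group of compound 2 alone. Compound 2 and compound 4 both stand as limits, so the step between them cannot be read.

Which part of 2-(4-methoxyphenyl)ethenyl goes with the step stays open: a plain phenyl or a 2-phenylethyl group on this carbonyl carbon would separate the methoxy group and the ethenyl link from the ring. Also open, as far as these compounds go, is whether an amine or a carboxylic acid on that ring would keep the read-out at such a limit.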